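The source may report more compounds than this note shows. Statements on the series, on what has been measured and on what is new or still open speak of the compounds shown alone.

Of the compounds shown here, two built on a shared core have been measured in an assay on cell membranes for antagonist activity at adenosine receptor A1 (Rattus norvegicus); a higher number here means a weaker inhibitor, a lower number a stronger inhibitor. Compound 1 `Cc1nc2c(=O)n(C)c(=O)n(C)c2[nH]1` gives 6500 nM, while compound 2 `Cn1c(=O)c2nc(-c3cccc(N)c3)[nH]c2n(C)c1=O` gives 1100 nM, the lowest of the two numbers. Compound 3 `Cn1c(=O)c2nc(-c3cccc(O)c3)[nH]c2n(C)c1=O` has not yet been measured; it differs from compound 2 in one place: hydroxy in place of amino on an aromatic carbon. Within the data shown here, no step between measured compounds is known, so nothing shows how such a change acts here. The step from compound 2 to compound 3 in this assay is expected to stay within the usual scatter, a 1.1-fold lower number from compound 2 to compound 3 (0.04 log units; within the scatter). Compound 3 is estimated at 1000 nM, between 300 nM and 3500 nM.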

Compound 3, inhibition constant: 340 nM
Compound 3: middle estimate off by 2.9-fold (0.47 log units), on the high side; measured number inside the range.
By their numbers in this assay, from the lowest: compound 3; then compound 2; then compound 1.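

At this place on the aromatic ring, meta to a large group, hydroxy in place of amino has a real effect in this assay (a 3.2-fold lower number from compound 2 to compound 3 (0.51 log units; beyond the scatter)). Swapping one nitrogen for one oxygen is enough to shift the number, even though the groups have the same counts of hydrogen-bond donors and acceptors. Nothing measured on these compounds explains the shift. Going by these compounds, how a methoxy group or a carboxylic acid would compare at this place remains open, as does the effect of hydroxy elsewhere on the ring.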